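Compound 4: methoxymethyl in place of a 1,2-dimethylpropyl chain

This account rests on a few compounds, and the source may have more. Where it says the series, first, only, none or still open, it means among the compounds named here.

Of the compounds shown here, three sharing one core have been measured in a functional assay on HeLa cells (Homo sapiens) for cytotoxicity, read by WST assay, with a stated time of 48 h; on this read-out lower numbers stand for stronger inhibition and higher numbers for weaker inhibition. Compound 1 (`COc1cc(C(c2ccc(O)c(OC)c2)[C@H](C)[C@H](C)CO)ccc1O`) gives > 100000 nM, which is a limit of the assay and not a number. Compound 2 (`COc1cc(C(c2ccc(O)c(OC)c2)[C@@H](C)[C@@H](C)CF)ccc1O`) gives 42000 nM, and compound 3 (`COc1cc(C(c2ccc(O)c(OC)c2)[C@@H](C)C(C)C)ccc1O`) gives 19000 nM. Compound 3 therefore holds the lowest number of the three, with compound 2 as its nearest neighbour.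

Compound 4 (`COC[C@H](C)[C@@H](C)C(c1ccc(O)c(OC)c1)c1ccc(O)c(OC)c1`) has not yet been measured. It carries 2-(methoxymethyl)-1-methylpropyl in place of 1,2-dimethylpropyl on a saturated chain carbon bound to two aromatic carbons.

Among the measured compounds shown here, three measured steps bear on this change. Exchanging the hydroxymethyl chain for 1,2-dimethylpropyl gave an at least 5.2-fold lower number from compound 1 to compound 3 (0.72 log units; beyond the scatter), and exchanging it for the fluoromethyl chain gave an at least 2.3-fold lower number from compound 1 to compound 2 (0.37 log units; beyond the scatter). Hydrogen in place of fluoro then gave a 2.2-fold lower number from compound 2 to compound 3 (0.34 log units; beyond the scatter). Among these three compounds, the chain without oxygen or fluoro thus has the lowest number. Compound 4 regains an oxygen, as in compound 1, though as methoxymethyl rather than hydroxymethyl. A modest rise in the number is therefore expected in this assay, close in size to the gap between compound 2 at 42000 nM and compound 3 at 19000 nM. The expected change is a 2.1-fold higher number from compound 3 to compound 4 (0.32 log units; beyond the scatter). The estimate for compound 4 is 40000 nM, with an expected range of 15000 nM to 100000 nM.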

Compound 4, half-maximal inhibitory concentration: 77000 nM
Beside the measured number, compound 4's estimate is 1.9-fold (0.28 log units) below it, and the stated range covers the measured number.
By their numbers in this assay, from the lowest: compound 3; then compounds 2 and 4 (each within the scatter of the next). At a limit, above all of these: compound 1.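

In this assay, 2-(methoxymethyl)-1-methylpropyl in place of 1,2-dimethylpropyl gives a 4.1-fold higher number from compound 3 to compound 4 (0.61 log units; beyond the scatter), which puts a size on the cost of an oxygen-bearing chain at this position relative to the 1,2-dimethylpropyl chain. Against the fluoromethyl chain, the methoxymethyl chain gives a 1.8-fold higher number from compound 2 to compound 4 (0.26 log units; within the scatter), so these two chains cannot be told apart in this assay, while compound 3 keeps the lowest number of the set. The hydroxymethyl chain of compound 1 is read only as a limit of the assay, and the step to the methoxymethyl chain, an at least 1.2-fold lower number from compound 1 to compound 4 (0.11 log units; that floor lies within the scatter), sets no order between the two chains: the limit of > 100000 nM in this assay, at which 1 of the 4 values shown sits.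

The compounds shown leave open whether the rise seen with compound 4 comes from the oxygen itself or from the longer chain, since the two arrive together in this one change. They also leave open how an amine or a carboxylic acid in place of the methoxymethyl group, or a simple longer chain of carbons alone at this position, would compare with the 1,2-dimethylpropyl chain.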